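A few compounds are considered here, and "the series" means these few. Any claim that something is new, unique, unknown or untested is made for them only; others in the source may bear on it.

Among the measured compounds shown here, in a functional assay on KB cells (Homo sapiens) for cytotoxicity (on this read-out higher numbers stand for weaker inhibition and lower numbers for stronger inhibition), compound 1 `COc1ccc(S(=O)(=O)N2CCc3cccc(NC(=O)C(C)(C)C)c32)cc1` gives 359 nM, while compound 2 `COc1ccc(S(=O)(=O)N2CCc3cccc(NC(=O)c4ccncc4)c32)cc1` gives 9.6 nM, the lower of the only two numbers measured. Compound 3 `COc1ccc(S(=O)(=O)N2CCc3cccc(NS(=O)(=O)c4ccccc4)c32)cc1` has not yet been measured. It differs from compound 2 at a single place: phenylsulfonyl in place of (pyridin-4-yl)carbonyl on a nitrogen on an aromatic ring. The carbonyl link and the pyridin-4-yl ring therefore both go at once. For the measured compounds named here, only one measured step bears on this, a 37-fold lower number from compound 1 to compound 2 (1.57 log units; beyond the scatter). That large step changed just the group on the carbonyl carbon, so the number clearly responds strongly to change at this part of the molecule. Going by the values given here, no measured compound shows what replacing the carbonyl with a sulfonyl does. Among the compounds with values here, with compound 2 at the low end of the numbers so far, a large move to a higher number is expected, a 31-fold higher number from compound 2 to compound 3 (1.49 log units; beyond the scatter). Compound 3 is estimated at 300 nM, with an expected range from 40 nM to 2500 nM.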

Compound 3, half-maximal inhibitory concentration: 650 nM
Estimate against measurement, compound 3: 2.2-fold (0.34 log units) below; low and high end bracket the measured number.
By their numbers in this assay, from the lowest: compound 2; then compounds 1 and 3 (each within the scatter of the next).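

In this assay, the low number of compound 2 does not survive the exchange of (pyridin-4-yl)carbonyl for phenylsulfonyl on this nitrogen (a 68-fold higher number from compound 2 to compound 3 (1.83 log units; beyond the scatter)), so a second aromatic ring at this place is not enough to keep it. Among the compounds shown here, compound 3 instead falls level with the compound carrying (tert-butyl)carbonyl (a 1.8-fold higher number from compound 1 to compound 3 (0.26 log units; within the scatter)), which leaves (pyridin-4-yl)carbonyl as the only one of the three groups with a low number. Nothing available here explains this difference.

The link and the ring changed together, so the step cannot be divided between them. A benzoyl group would test the ring with the carbonyl kept, and a (pyridin-4-yl)sulfonyl group would test the sulfonyl with the ring kept.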